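The source may report more compounds than this note shows. Statements on the series, on what has been measured and on what is new or still open speak of the compounds shown alone.

In a functional assay on HO8910 cells (Homo sapiens) for inhibition, read by MTT assay, with a stated time of 24 h, tested at 1 ug/mL (a higher number here means more inhibition of growth at the concentration tested, a lower number less inhibition of growth), compound 1 (`O=C(CCCCC1CCSS1)Nc1ccc([N+](=O)[O-])c(C(F)(F)F)c1`) gives 0.96% and compound 2 (`O=C(CCCCC(S)CCS)Nc1cccc(C(F)(F)F)c1`) gives 13.7%. Compound 2 is thus the higher of the two, with a gap beyond the scatter, but the two structures differ in more than one place, so no single change can be read from that gap. Compound 3 (`O=C(CCCCC(S)CCS)Nc1ccc([N+](=O)[O-])c(C(F)(F)F)c1`) departs from compound 2 in one place: nitro in place of hydrogen on an aromatic carbon, with nitro in place of hydrogen on an aromatic carbon, ortho to a trifluoromethyl group and para to a large group. Among the compounds with values here, no measured pair isolates this change. The nitro group is shared with compound 1, which gives 0.96%, so a small downward move in this assay, within the scatter, is expected. The expected shift is a number 3.7 percentage points lower from compound 2 to compound 3 (within the scatter). For compound 3 the estimated value is 10%, with an expected range of 1% to 24%.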

Compound 3, percent growth inhibition at one concentration: 1.17%
Estimate against measurement, compound 3: 8.8 percentage points above, and the stated range covers the measured number.
By their numbers in this assay, from the lowest: compounds 1 and 3 (each within the scatter of the next); then compound 2.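

In this assay, nitro in place of hydrogen on an aromatic carbon, ortho to a trifluoromethyl group and para to a large group, gives a number 12.5 percentage points lower from compound 2 to compound 3 (beyond the scatter), so this pair now isolates the change at this position. With the nitro group present, replacing the group with one five-membered non-aromatic ring by the ring-free group of the same heavy-atom count gives a number 0.2 percentage points higher from compound 1 to compound 3 (within the scatter), so the two side chains cannot be told apart on this core. Nothing available explains the size of either step.

The compounds shown leave open whether the ring-bearing side chain would also stand apart from the ring-free one without the nitro group. They also leave open whether an amine or a nitrile at that aromatic carbon would give a step like the one seen for nitro.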